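Shifting chlorines on the aryl group at the ring nitrogen

The source may report more compounds than this note shows. Statements on the series, on what has been measured and on what is new or still open speak of the compounds shown alone.

Measured so far in an assay on CHO cells for displacement of a labelled ligand from adenosine receptor A3 (Homo sapiens), read by scintillation counting, with a stated time of 120 min, tested at 10 uM; on this read-out higher numbers stand for more inhibition at the one concentration tested (going by the name of the read-out) and lower numbers for less inhibition:
compound 1 `Nc1scc(CN2CCN(c3cccc(F)c3F)CC2)c1C(=O)c1ccc(Cl)cc1` gives 0%
compound 2 `Nc1scc(CN2CCN(c3c(Cl)cccc3Cl)CC2)c1C(=O)c1ccc(Cl)cc1` gives 1%

Compound 2 shows the higher of the two numbers, yet compound 1 lies within the scatter of it, so no order between them can be read. Among the compounds with values here, the single measured step, a number 1 percentage points higher from compound 1 to compound 2 (within the scatter), exchanged one aryl group for another on the amine nitrogen in the ring and left the read-out where it was.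

Compound 3 `Nc1scc(CN2CCN(c3cc(Cl)ccc3Cl)CC2)c1C(=O)c1ccc(Cl)cc1` is the next member. (2,5-dichlorophenyl in place of 2,6-dichlorophenyl on an amine nitrogen in a ring). Within the data shown here, the only step that bears on this change is the one from compound 1 to compound 2, which also altered the aryl group at the same place and stayed within the scatter. No step beyond the scatter is therefore expected in this assay. The step expected for compound 3 is a number 1 percentage points higher from compound 2 to compound 3 (within the scatter). Compound 3 is estimated at 2%, with a range from -7% to 12%.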

Compound 3, a percentage reported as inhibition, at one concentration (the size of the read-out at that concentration, not a potency): 1%
Beside the measured number, compound 3's estimate is 1 percentage points above it, within the range that was stated.
By their numbers in this assay, from the lowest: compounds 1, 2 and 3 (each within the scatter of the next).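

In this assay, moving one chlorine, from 2,6-dichlorophenyl to 2,5-dichlorophenyl with the same atoms joined differently, gives no change at the digits printed from compound 2 to compound 3 (within the scatter), so this placement change on the amine nitrogen in a ring does not separate the two compounds. Replacing 2,3-difluorophenyl with 2,5-dichlorophenyl gives a number 1 percentage points higher from compound 1 to compound 3 (within the scatter), which puts all three aryl groups at this place within the scatter of one another. Nothing at hand offers a reason for this flat read-out.

With all three numbers this close, the series gives no ranking of the aryl groups in this assay. Open, going by these compounds, is whether a methoxy group or a carboxylic acid on the aryl ring, or a benzyl group in place of the aryl group, would move the read-out beyond the scatter.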